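A few compounds are considered here, and "the series" means these few. Any claim that something is new, unique, unknown or untested is made for them only; others in the source may bear on it.

Working notes on the sulfonyl series.

Compound 3 `COc1ccc(C2=NOC(c3ccc(C)cc3)C2S(=O)(=O)CC2=NCCS2)cc1` and compound 2 `COc1ccc(C2=NOC(c3ccc(C)cc3)C2S(=O)(=O)CC2=NCCO2)cc1` share one core and differ only in a group of 5 heavy atoms (3 carbon, 1 nitrogen, 1 oxygen; one five-membered non-aromatic ring with 2 hetero atoms) in place of a group of 5 heavy atoms (3 carbon, 1 nitrogen, 1 sulfur; one five-membered non-aromatic ring with 2 hetero atoms), on a saturated chain carbon bound to a sulfonyl sulfur. In a functional assay, read by Griess assay, with a stated time of 150 min, tested at 50 ug/mL (a lower number here means a weaker effect, a higher number a stronger effect of the compound at the concentration tested), compound 3 gives 48.6%, and compound 2 gives 61.9%; the step is a number 13.3 percentage points higher from compound 3 to compound 2 (beyond the scatter).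

Compound 1 `O=S(=O)(CC1=NCCS1)C1C(c2ccccc2)=NN(c2ccccc2)C1c1ccccc1` has a different core; the difference between the two cores is not broken down here. In this assay compound 1 is reported as "not active" (no number reported), so no number is available for it.

Compound 4 `O=S(=O)(CC1=NCCO1)C1C(c2ccccc2)=NN(c2ccccc2)C1c1ccccc1` is not yet measured. It differs from compound 1 in a group of 5 heavy atoms (3 carbon, 1 nitrogen, 1 oxygen; one five-membered non-aromatic ring with 2 hetero atoms) in place of a group of 5 heavy atoms (3 carbon, 1 nitrogen, 1 sulfur; one five-membered non-aromatic ring with 2 hetero atoms), on a saturated chain carbon bound to a sulfonyl sulfur, the same change as that from compound 3 to compound 2, at the same place. From the compounds shown here alone, a step of similar size, modest and in the same direction, is expected from compound 1 to compound 4 in this assay, resting on a number 13.3 percentage points higher from compound 3 to compound 2 (beyond the scatter); the starting point, however, is unknown because compound 1 gives only "not active" (no number reported), so the outcome for compound 4 may again be reported without a number. On that basis compound 4 is estimated at 15%, with a range of 0% to 35%.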

Compound 4, a percentage reported as activity, at one concentration (the size of the read-out at that concentration, not a potency): 46.7%
Compound 4: middle estimate off by 31.7 percentage points, on the low side; the whole stated range lies below it.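

In this assay, among these compounds, compound 1 gives "not active" (no number reported) and compound 4 gives 46.7% as its reading, so no step from compound 1 to compound 4 can be read. The compounds shown leave open whether the same group change on this core matches a number 13.3 percentage points higher from compound 3 to compound 2 (beyond the scatter) in size. No supporting data bear on this result.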